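The compounds below may be only part of what the source reports. "The series", "measured", "known", "first", "only" and "open" are said of these compounds alone.

Measured in a functional assay on MCF7 cells (Homo sapiens) for antiproliferative activity, read by MTT assay, with a stated time of 48 h; a lower number here means a stronger inhibitor, a higher number a weaker inhibitor:
- compound 1 `N#Cc1cccc(Nc2ncnc3cc(NC(=O)/C=C/c4ccccc4)sc23)c1`: > 100000 nM
- compound 2 `COc1ccc(/C=C/C(=O)Nc2cc3c(Nc4cc(Cl)cc(Cl)c4)ncnc3s2)cc1`: 75600 nM

Compound 1 has only a limit of the assay, > 100000 nM, and not a number. Compound 3 `O=C(/C=C/c1ccccc1)Nc1cc2ncnc(Nc3cc(Cl)cc(Cl)c3)c2s1` has not been measured. It shares the core of compound 1 and carries 3,5-dichlorophenyl in place of 3-cyanophenyl on a nitrogen on an aromatic ring. Within the data shown here, no measured step gives the size of this change. Compound 2, which also bears 3,5-dichlorophenyl, gives 75600 nM, so a small step towards stronger inhibition is expected in this assay. A further reading at the limit would be no surprise. The estimate means an at least 1.6-fold lower number from compound 1 to compound 3 (0.22 log units; that floor lies within the scatter), an expected modest gain. For compound 3 the expected value is 60000 nM, with an estimated range of 20000 nM to 100000 nM.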

Compound 3, half-maximal inhibitory concentration: > 100000 nM
Compound 3 was reported as a limit (the forecaster's own chance of this, stated with the estimate: 40%); middle value at least 1.6-fold (0.22 log units) away from the limit.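

No step can be read from compound 1 to compound 3, because both readings in this assay are limits and not numbers: the limit of > 100000 nM in this assay, at which 2 of the 3 values shown sit.

From the compounds shown here alone, whether 3,5-dichlorophenyl in place of 3-cyanophenyl on the shared core changes the read-out remains open.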